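Methoxymethoxy in place of hydroxy: working notes on the series

The source may hold more compounds than are shown below. What is called first, only, known or untested is meant among the compounds shown, and "the series" means these compounds.

- compound 1 `CCCCC/C=C\C/C=C\CCCCCCCc1cc(=O)c2c(O)c(C)c(OCOC)c(C)c2o1` gives > 84100 nM in a functional assay on MCF7 cells (Homo sapiens) for antiproliferative activity, read by MTT assay (on this read-out higher numbers stand for weaker inhibition and lower numbers for stronger inhibition), as a limit, not a number
- compound 2 `CCCCC/C=C\C/C=C\CCCCCCCc1cc(=O)c2c(O)cc(O)c(C)c2o1` gives 17500 nM in this assay as a measured number

Among the measured compounds shown here, compound 2 holds the only measured number so far, and the one other value is a limit. Compound 3 `CCCCC/C=C\C/C=C\CCCCCCCc1cc(=O)c2c(O)cc(OCOC)c(C)c2o1` follows from compound 2 by putting methoxymethyl in place of hydrogen on an oxygen on an aromatic ring, hydroxy to methoxymethoxy methoxymethyl in place of hydrogen on an oxygen on an aromatic ring in the piece of structure concerned. For the measured compounds named here, no measured pair isolates this change. Going by the values given here, the only guide is compound 1, which carries a methoxymethoxy group and gives the limit > 84100 nM in this assay here. Weaker inhibition is therefore expected, with a modest step beyond the scatter. The expected change is a 2.0-fold higher number from compound 2 to compound 3 (0.30 log units; within the scatter) in this assay as estimated. Compound 3 is estimated at 35000 nM with an expected range from 12000 nM to 90000 nM in this assay as a measured value.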

Compound 3, half-maximal inhibitory concentration: > 84100 nM
Compound 3 ended at the assay's limit; the forecaster's own chance of this, stated with the estimate: 35%; at least 2.4-fold (0.38 log units) between middle value and limit.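

In this assay, among the compounds shown here, methoxymethyl in place of hydrogen on an oxygen on an aromatic ring gives the first readable step: an at least 4.8-fold higher number from compound 2 to compound 3 (0.68 log units; beyond the scatter). For the compounds shown here, compound 1 already carried a methoxymethoxy group but had no partner differing from it in one place, so this pair is the first to tie weaker inhibition to the change from hydroxy to methoxymethoxy on the shared core. The step gives only a minimum size, and the full size stays hidden at the limit of the read-out: the limit of > 84100 nM in this assay, at which 2 of the 3 values shown sit.

Compound 1 and compound 3 both stand at limits, and the step between them cannot be read. On these data alone, whether a methoxy group or an amine in place of this hydroxy would keep inhibition near the level of compound 2 remains open.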